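Anilinoquinazoline acrylamides: swapping the aryl on the enamide

The compounds below may be only part of what the source reports. "The series", "measured", "known", "first", "only" and "open" are said of these compounds alone.

Measured compounds:
- compound 1 `COc1ccc(OC)c(/C=C/C(=O)Nc2cc3c(Nc4ccc(F)c(Cl)c4)ncnc3cc2O[C@H]2CCOC2)c1` — 26800 nM
- compound 2 `COc1cc2ncnc(Nc3ccc(F)c(Cl)c3)c2cc1NC(=O)/C=C/c1ccccc1[N+](=O)[O-]` — "not determined" (no result reported)

In a functional assay on HeLa cells (Homo sapiens) for cytotoxicity, read by MTT assay, with a stated time of 72 h (on this read-out lower numbers stand for stronger inhibition and higher numbers for weaker inhibition), compound 1 gives 26800 nM. Among the compounds with values here, this is the only number: compound 2 carries the same enamide with a 2-nitrophenyl end but a different alkoxy group on the shared core, and for compound 2 the result in this assay was "not determined" (no result reported), so no comparison between measured compounds is available.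

Compound 3 `O=C(/C=C/c1ccccc1[N+](=O)[O-])Nc1cc2c(Nc3ccc(F)c(Cl)c3)ncnc2cc1O[C@H]1CCOC1` is not yet measured. It keeps the core and the alkoxy group of compound 1 and differs only at the enamide end: 2-nitrophenyl in place of 2,5-dimethoxyphenyl on a double-bonded chain carbon bound to a double-bonded chain carbon. Within the data shown here, no step between measured compounds has been recorded, so the size of this change can only be anticipated. With nothing in the series to indicate a direction, a step from compound 1 to compound 3 of no more than the usual scatter is expected, with a wide range to either side, a 1.3-fold lower number from compound 1 to compound 3 (0.13 log units; within the scatter). Compound 3 is therefore estimated at 20000 nM in this assay, between 5000 nM and 80000 nM.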

Compound 3, half-maximal inhibitory concentration: 29600 nM
Compound 3: middle estimate off by 1.5-fold (0.17 log units), on the low side; the range from low to high includes it.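

Within the data shown here, the first readable step lies at the enamide end: in this assay, 2-nitrophenyl in place of 2,5-dimethoxyphenyl on a double-bonded chain carbon bound to a double-bonded chain carbon gives a 1.1-fold higher number from compound 1 to compound 3 (0.04 log units; within the scatter) on an otherwise identical structure. Within this single pair, the two aryl ends cannot be told apart in this read-out, although one carries two methoxy groups and the other a nitro group, and both have one six-membered aromatic ring of carbon only and the same count of hydrogen-bond acceptors. No supporting measurement accompanies the pair, and the step therefore stands as a size with no explanation attached.

As far as these compounds go, two aryl ends give no basis for a rule about this position, and it remains open whether any group placed here would separate from compound 1 in this read-out. A phenyl ring carrying a dimethylamino group or a carboxylic acid, or a longer alkyl chain in place of the aryl ring, would test this end of the molecule more widely.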